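Chloro for bromo on the fused ring

A few compounds are considered here, and "the series" means these few. Any claim that something is new, unique, unknown or untested is made for them only; others in the source may bear on it.

Measured so far:
compound 1 `COc1ccc(C2=NN(C3=NC(=O)/C(=C4\C(=O)Nc5ccc(Cl)cc54)S3)C(c3ccc(OC)cc3)C2)cc1` — 190 nM
compound 2 `COc1ccc(C2=NN(C3=NC(=O)/C(=C4\C(=O)Nc5ccccc54)S3)C(c3ccc(Cl)cc3)C2)cc1` — 100000 nM
compound 3 `COc1ccc(C2=NN(C3=NC(=O)/C(=C4\C(=O)Nc5ccc(Br)cc54)S3)C(c3ccc(Cl)cc3)C2)cc1` — 160 nM

All three numbers come from a functional assay on cells (Melanoma cell, Homo sapiens) for cytotoxicity, read by sulforhodamine B assay, with a stated time of 48 h; a lower number here means a stronger inhibitor of growth, a higher number a weaker inhibitor of growth. In this assay compound 3 gives 160 nM, the lowest of the three, but compound 1 with 190 nM sits within the scatter of it. Compound 2 is far apart: a 630-fold lower number from compound 2 to compound 3 (2.80 log units; beyond the scatter).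

The next compound is compound 4 `COc1ccc(C2=NN(C3=NC(=O)/C(=C4\C(=O)Nc5ccc(Cl)cc54)S3)C(c3ccc(Cl)cc3)C2)cc1`. It differs from compound 3 in one place: chloro in place of bromo on an aromatic carbon.

Going by the values given here, no measured step compares chloro with bromo directly. Among the compounds with values here, the one step that touches this position, the change from compound 2 to compound 3, shows what the presence of a group there does against hydrogen, and it is large; it says nothing about exchanging one such group for another. Compound 1 carries chloro at the same place, though it also differs from compound 3 on the pendant phenyl, and its value and that of compound 3 lie within the scatter of each other.

On that basis no step beyond the scatter is expected for compound 4: a 1.1-fold higher number from compound 3 to compound 4 (0.05 log units; within the scatter). Compound 4 is estimated at 180 nM, with a range from 80 nM to 400 nM.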

Compound 4, concentration for 50% growth inhibition: 200 nM
The estimate for compound 4 lay 1.1-fold (0.05 log units) below the measured number; measured number inside the range.
By their numbers in this assay, from the lowest: compounds 3, 1 and 4 (each within the scatter of the next); then compound 2.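

Bromo and chloro can now be compared directly on the fused ring: in this assay the exchange stays within the scatter (a 1.3-fold higher number from compound 3 to compound 4 (0.10 log units; within the scatter)), while chloro against hydrogen gives a large step (a 500-fold lower number from compound 2 to compound 4 (2.70 log units; beyond the scatter)), so the gain over hydrogen seen with bromo is also seen with chloro. With chloro on the fused ring, the second place in the series can carry either chloro or methoxy without a step beyond the scatter (a 1.1-fold higher number from compound 1 to compound 4 (0.02 log units; within the scatter)), which compound 1 alone could not show because it differed from compound 3 in two places. No measurement on hand accounts for these steps or for the large difference from hydrogen.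

From the compounds shown here alone, only bromo, chloro and hydrogen are compared on the fused ring, so it remains open whether an amine, a carboxylic acid or a methoxy group there would give numbers near those of compound 3 and compound 4 or near that of compound 2. Going by these compounds, at the second place, only chloro and methoxy are compared, and it remains open whether a longer chain such as butoxy or an amine would keep the number level.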